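Series notes: ether variation at the chloro-substituted aryl position

A few compounds are considered here, and "the series" means these few. Any claim that something is new, unique, unknown or untested is made for them only; others in the source may bear on it.

Of the compounds shown here, two have been measured in an ADME assay on MDCKII-LE cells (Canis lupus familiaris) for permeability; on this read-out lower numbers stand for lower permeability and higher numbers for higher permeability. Compound 1 `Cc1cc(C)c(CN2CCc3c(Cl)cc(-c4c(C)noc4C)c(Cl)c3C2=O)c(=O)[nH]1` gives 15.7 10^-6 cm/s. Compound 2 `Cc1cc(C)c(CN2CCc3ccc(OC(C)C)c(Cl)c3C2=O)c(=O)[nH]1` gives 19.6 10^-6 cm/s. Compound 2 stands highest of the two numbers, but its nearest neighbour is compound 1, and the gap between them lies within the scatter, so the two values cannot be ordered.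

Compound 3 `Cc1cc(C)c(CN2CCc3ccc(O[C@@H]4CCOC4)c(Cl)c3C2=O)c(=O)[nH]1` is the next compound, differing from compound 2 in one place: oxolan-3-yl in place of isopropyl on an oxygen on an aromatic ring. For the measured compounds named here, no step between measured compounds addresses a change of this kind, so the expectation rests on compound 2 alone. A modest downward step is expected, estimated as a 1.6-fold lower number from compound 2 to compound 3 (0.21 log units; within the scatter), close to the edge of the scatter rather than clearly beyond it. Compound 3 is therefore expected to give 12 10^-6 cm/s in this assay, with a plausible range from 6 10^-6 cm/s to 22 10^-6 cm/s.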

Compound 3, apparent permeability in the MDCKII-LE assay: 12.3 10^-6 cm/s
Compound 3: middle estimate off by 1.0-fold (0.01 log units), on the low side; the measured number falls inside the stated range.
By their numbers in the MDCKII-LE assay, from the lowest: compounds 3, 1 and 2 (each within the scatter of the next).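

In the MDCKII-LE assay, oxolan-3-yl in place of isopropyl on an oxygen on an aromatic ring gives a 1.6-fold lower number from compound 2 to compound 3 (0.20 log units; within the scatter), so this position accepts the added ring and hydrogen-bond acceptor with no change that can be read in this assay. In a physicochemical assay for solubility, measured as kinetic solubility (a higher number here means a more soluble compound, a lower number a less soluble compound), compound 2 gives 19600 nM and compound 3 gives 510000 nM. Of the two read-outs, only solubility shifts beyond the scatter with this change: the measured solubility of compound 2, 19600 nM, and of compound 3, 510000 nM, a 26-fold higher number (1.42 log units; beyond the scatter)

The compounds shown do not separate the contribution of the ring from that of its oxygen, and they do not show how the opposite configuration at the defined stereocentre would read. From the compounds shown here alone, how an open methoxyethyl chain or a piperidin-4-yl amine on the same oxygen would fare in either read-out also remains open.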